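A few compounds are considered here, and "the series" means these few. Any claim that something is new, unique, unknown or untested is made for them only; others in the source may bear on it.

In a functional assay on B16-BL6 cells (Mus musculus) for cytotoxicity, read by MTT assay, with a stated time of 48 h (on this read-out higher numbers stand for weaker inhibition and lower numbers for stronger inhibition), compound 1 `CNC(=O)c1ccc(Sc2ccc(NC(=S)Nc3cc(C(F)(F)F)cc(C(F)(F)F)c3)cc2)nc1` gives 36100 nM. Compound 2 `CNC(=O)c1ccc(Sc2cccc(NC(=S)Nc3ccc(Br)c(C(F)(F)F)c3)c2)nc1` returns only a limit of the assay in this assay, > 100000 nM. Compound 2 therefore sits at the limit of > 100000 nM in this assay, at which 1 of the 2 values shown sits, the weak end of the two numbers shown, with no value of its own to anchor a step. Compound 3 `CNC(=O)c1ccc(Sc2cccc(NC(=S)Nc3cccc(C(F)(F)F)c3)c2)nc1` differs from compound 2 in one place: hydrogen in place of bromo on an aromatic carbon. Among the compounds with values here, no measured step of this kind exists. The expected step that the limit leaves unreadable from compound 2 to compound 3 is small, none beyond the scatter in this assay. Compound 3 is thus estimated at 120000 nM in this assay, with a likely range from 40000 nM to 400000 nM, and a limit-only result remains the more probable outcome.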

Compound 3, half-maximal inhibitory concentration: 19200 nM
Estimate against measurement, compound 3: 6.3-fold (0.80 log units) above, and the stated range ends above it.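

In this assay, hydrogen in place of bromo on an aromatic carbon, ortho to a trifluoromethyl group and para to a large group, gives an at least 5.2-fold lower number from compound 2 to compound 3 (0.71 log units; beyond the scatter). Compound 2 gives only a limit of the assay, > 100000 nM. This position therefore responds to the change, and the step is a lower bound on its size, not a measured size.

Open, going by these compounds, is how a chloro, a methoxy or an amine at this position would read. Also open, on these data alone, is whether removing bromo has the same effect on a different core.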